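Working notes: from compound 2 to compound 3

A few compounds are considered here, and "the series" means these few. Any claim that something is new, unique, unknown or untested is made for them only; others in the source may bear on it.

Values so far in a functional assay on SW-620 cells (Homo sapiens) for antiproliferative activity, read by MTT assay, with a stated time of 24 h; on this read-out higher numbers stand for weaker inhibition and lower numbers for stronger inhibition:
compound 1 (`COc1ccc(C(=O)/C=C/c2ccco2)c2c1C=CC(C)(C)O2`) gives > 10000 nM as a limit
compound 2 (`COc1ccc(C(=O)/C=C/c2ccc(O)cc2)c2c1C=CC(C)(C)O2`) gives > 10000 nM as a limit

Compound 2 stands only at a limit in this assay and has no number. The evidence so far is the limit of > 10000 nM in this assay, at which 2 of the 2 values shown sit, and nothing more. Among the measured compounds shown here, the one measured step is a step that the two limits leave unreadable from compound 1 to compound 2 and offers no size to carry forward. Compound 3 (`COc1ccc(C(=O)/C=C/c2cc(Cl)ccc2O)c2c1C=CC(C)(C)O2`) follows from compound 2 by a single change (5-chloro-2-hydroxyphenyl in place of 4-hydroxyphenyl on a double-bonded chain carbon bound to a double-bonded chain carbon) on the same chain. For the measured compounds named here, no measured step covers this exchange, and the data give neither a size nor a direction for it. Because of the limit of > 10000 nM in this assay, at which 2 of the 2 values shown sit, a result at the same limit is expected for compound 3 too. The expected step is a step that the limit leaves unreadable from compound 2 to compound 3 as an estimate only. Compound 3 is estimated at 12000 nM (4000 nM to 30000 nM) as an expected value.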

Compound 3, half-maximal inhibitory concentration: 4230 nM
Beside the measured number, compound 3's estimate is 2.8-fold (0.45 log units) above it, within the range that was stated.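

In this assay, this place on the chain can carry the read-out off the limit: the exchange for 5-chloro-2-hydroxyphenyl gives an at least 2.3-fold lower number from compound 2 to compound 3 (0.37 log units; beyond the scatter), and the exchange for the same group in place of furan-2-yl gives an at least 2.3-fold lower number from compound 1 to compound 3 (0.37 log units; beyond the scatter). The step between the other two compounds cannot be read, so furan-2-yl and 4-hydroxyphenyl remain unranked against each other. Compound 3 is the only one of the three with a number, which makes it the first reference value for this place, while the others remain at a limit: the limit of > 10000 nM in this assay, at which 2 of the 3 values shown sit.

The exchange in compound 3 adds chlorine and also changes the hydroxy-bearing aryl group, and the compounds shown do not separate these two changes. On these data alone, whether 2-hydroxyphenyl without chlorine, or 4-chlorophenyl, would also give a number remains open.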